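The compounds below may be only part of what the source reports. "The series", "measured", "known", "first", "only" and "open" are said of these compounds alone.

Measured so far:
- compound 1 `C[C@H]1CC[C@@H]2[C@@H](OC(=O)[C@]23CC(c2c(Cl)cccc2Cl)=NO3)[C@]2(C)C(=O)C=C[C@@]12O`: 56000 nM
- compound 2 `COc1ccc(C2=NO[C@]3(C2)C(=O)O[C@@H]2[C@H]3CC[C@H](C)[C@]3(O)C=CC(=O)[C@@]23C)cc1OC`: 25000 nM
- compound 3 `C[C@H]1CC[C@@H]2[C@@H](OC(=O)[C@]23CC(c2cccc([N+](=O)[O-])c2)=NO3)[C@]2(C)C(=O)C=C[C@@]12O`: 55000 nM

In a functional assay on PC-3 cells (Homo sapiens) for cytotoxicity, read by sulforhodamine B assay, with a stated time of 48 h (on this read-out lower numbers stand for stronger inhibition and higher numbers for weaker inhibition), compound 3 gives 55000 nM, which matches compound 1 within the scatter: a 1.0-fold lower number from compound 1 to compound 3 (0.01 log units; within the scatter). Compound 2 stands apart, with a 2.2-fold higher number from compound 2 to compound 3 (0.34 log units; beyond the scatter).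

Compound 4 `C[C@H]1CC[C@@H]2[C@@H](OC(=O)[C@]23CC(c2ccc(C#N)cc2)=NO3)[C@]2(C)C(=O)C=C[C@@]12O` changes one group: 4-cyanophenyl in place of 3-nitrophenyl on a carbon with a double bond to nitrogen. It carries 4-cyanophenyl in place of 3-nitrophenyl on a carbon with a double bond to nitrogen.

Going by the values given here, the steps that bear on this replace the group at that same place. Besides the two above, there is a 2.2-fold lower number from compound 1 to compound 2 (0.35 log units; beyond the scatter). Among the compounds with values here, all are small, and no measured compound carries 4-cyanophenyl. No step beyond the scatter is therefore expected in this assay.

The expected change is a 1.2-fold lower number from compound 3 to compound 4 (0.09 log units; within the scatter).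

For compound 4 the estimated value is 45000 nM, with an expected range of 20000 nM to 90000 nM.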

Compound 4, half-maximal inhibitory concentration: 32000 nM
The estimate for compound 4 lay 1.4-fold (0.15 log units) above the measured number; measured number inside the range.
By their numbers in this assay, from the lowest: compounds 2, 4, 3 and 1 (each within the scatter of the next, the first and the last beyond it).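

In this assay, 4-cyanophenyl at this position gives a 1.7-fold lower number from compound 3 to compound 4 (0.24 log units; within the scatter) and a 1.8-fold lower number from compound 1 to compound 4 (0.24 log units; within the scatter) and also a 1.3-fold higher number from compound 2 to compound 4 (0.11 log units; within the scatter) in a single comparison set, so compound 4 cannot be told apart from any of the other three. Compound 1 and compound 2 do lie beyond the scatter of each other, yet compound 4 falls within the scatter of both, which blurs that earlier gap between aryl groups. No measurement here explains these results.

Still open, on these data alone, is whether a group with no phenyl ring at this place, such as an amine, a carboxylic acid or a longer alkyl chain, would give a clear step from compound 4.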